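Aryl-triazole variants on a shared core: antiproliferative notes

The compounds below may be only part of what the source reports. "The series", "measured", "known", "first", "only" and "open" are said of these compounds alone.

Three members of the series have been measured in a functional assay on HCT-116 cells (Homo sapiens) for antiproliferative activity, read by MTT assay, with a stated time of 48 h; a lower number here means a stronger inhibitor, a higher number a weaker inhibitor. Compound 1 `N#CC1=C(N)Oc2c(c3nc4ccccc4nc3c3ccccc23)C12C(=O)N(Cc1cnnn1-c1ccc(F)cc1)c1ccccc12` carries a 4-fluorophenyl on an aromatic nitrogen of the five-membered aromatic ring with 3 nitrogen, compound 2 `N#CC1=C(N)Oc2c(c3nc4ccccc4nc3c3ccccc23)C12C(=O)N(Cc1cnnn1-c1ccc(Cl)cc1)c1ccccc12` a 4-chlorophenyl and compound 3 `CCOc1ccccc1-n1nncc1CN1C(=O)C2(C(C#N)=C(N)Oc3c2c2nc4ccccc4nc2c2ccccc32)c2ccccc21` a 2-ethoxyphenyl at the same place.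

In this assay compound 1 gives > 50000 nM, which is a limit of the assay and not a number. Compound 2 likewise reaches only the limit > 50000 nM. Compound 3 also stops at the limit > 50000 nM. Consequently a step that the two limits leave unreadable from compound 1 to compound 2, a step that the two limits leave unreadable from compound 1 to compound 3 and a step that the two limits leave unreadable from compound 2 to compound 3 cannot be sized, since every value sits on (the limit of > 50000 nM in this assay, at which 3 of the 3 values shown sit). Compound 3 therefore stands exactly where the whole measured set stands, at the limit, with no number that would separate it from compounds 1 and 2.

Compound 4 `N#CC1=C(N)Oc2c(c3nc4ccccc4nc3c3ccccc23)C12C(=O)N(Cc1cnnn1-c1ccc([N+](=O)[O-])cc1)c1ccccc12` differs from compound 3 by 4-nitrophenyl in place of 2-ethoxyphenyl on an aromatic nitrogen. Among the compounds with values here, the steps that bear on this change are the three exchanges at this position among compounds 1, 2 and 3, and none of them is readable. No direction and no size emerge from them, so no step beyond the scatter can be predicted in this assay, and the expectation is that compound 4 also reports only the limit. Compound 4 is estimated at 60000 nM, in the range 20000 nM to 200000 nM, which corresponds to an expected step that the limit leaves unreadable from compound 3 to compound 4.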

Compound 4, half-maximal inhibitory concentration: > 50000 nM
Compound 4 gave a limit, no number (the forecaster's own chance of this, stated with the estimate: 85%); the middle value is on the limit's open side.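

In this assay compound 4 gives > 50000 nM, a limit of the assay and not a number. No step between compounds 1, 2, 3 and 4 can be read, because all four share one limit: the limit of > 50000 nM in this assay, at which 4 of the 4 values shown sit.

The compounds shown leave open whether any aryl group on this aromatic nitrogen would give a measurable value in this assay.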